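The source may report more compounds than this note shows. Statements on the series, on what has been measured and on what is new or still open speak of the compounds shown alone.

Compound 1 `O=C(Nc1cccc(-n2cc(-c3ccncc3)c(-c3ccc(Cl)c(O)c3)n2)c1)Nc1ccc(Cl)c(Cl)c1` is a urea, and in a functional assay on NCI-H226 cells (Homo sapiens) for inhibition, read by sulforhodamine B assay, with a stated time of 48 h (a higher number here means a weaker inhibitor of growth, a lower number a stronger inhibitor of growth), compound 1 gives 1510 nM. Two amides are measured beside it: compound 2 `COc1cc(-c2nn(-c3cccc(NC(=O)c4ccc(Cl)c(C(F)(F)F)c4)c3)cc2-c2ccncc2)ccc1Cl` gives 5900 nM in this assay, and compound 3 `COc1cc(-c2nn(-c3cccc(NC(=O)c4cccc(C(F)(F)F)c4)c3)cc2-c2ccncc2)ccc1Cl` gives 1660 nM. Among these three numbers compound 1 stands lowest; the number of compound 3 lies within the scatter of it, while compound 2 lies beyond the scatter above it. Among the measured compounds shown here, the one single-change step known here is a 3.6-fold lower number from compound 2 to compound 3 (0.55 log units; beyond the scatter), which concerns hydrogen in place of chloro on an aromatic carbon of the amide series.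

Compound 4 `O=C(Nc1cccc(-n2cc(-c3ccncc3)c(-c3ccc(Cl)c(O)c3)n2)c1)Nc1ccc(Cl)c(C(F)(F)F)c1` differs from compound 1 in one place: trifluoromethyl in place of chloro on an aromatic carbon. For the measured compounds named here, no measured step makes this same change; the step from compound 2 to compound 3 touches the same region but removes a chloro rather than exchanging one for trifluoromethyl, so it bears only loosely on the outcome. Going by the values given here, with no direct precedent, compound 4 is expected to stay near compound 1, with a 1.2-fold higher number from compound 1 to compound 4 (0.08 log units; within the scatter) as the expected step and no change beyond the scatter. Compound 4 is therefore estimated at 1800 nM in this assay, within a range from 700 nM to 4500 nM.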

Compound 4, concentration for 50% growth inhibition: 1350 nM
Compound 4: middle estimate off by 1.3-fold (0.12 log units), on the high side; the range from low to high includes it.
By their numbers in this assay, from the lowest: compounds 4, 1 and 3 (each within the scatter of the next); then compound 2.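

In the urea series, this assay gives a 1.1-fold lower number from compound 1 to compound 4 (0.05 log units; within the scatter), so on this aromatic carbon, ortho to a chloro group and meta to a large group, trifluoromethyl and chloro cannot be told apart in this measurement. Among the compounds shown here, the earlier compounds did not show this, as their only step, a 3.6-fold lower number from compound 2 to compound 3 (0.55 log units; beyond the scatter), removes a chloro within the amide series and exchanges nothing at the place now examined; the new pair shows that 3,4-dichlorophenyl and 4-chloro-3-(trifluoromethyl)phenyl can stand in each other's place on the urea without a change beyond the scatter. Nothing available here explains why the two ureas read alike.

As far as these compounds go, two groups of similar outcome at one place do not define what that place accepts, and it remains open whether a nitrile, an amine or a carboxylic acid there would keep the number of compound 1. From the compounds shown here alone, it also remains open whether hydrogen in place of the remaining chloro would move the number in the urea series as it does in the amide series, or whether the urea would hold it.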